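A few compounds are considered here, and "the series" means these few. Any claim that something is new, unique, unknown or untested is made for them only; others in the source may bear on it.

For the measured compounds named here, compound 2 `O=S(=O)(NCCCNc1nccc(-c2c(-c3cccc(F)c3)nc3sccn23)n1)c1ccc(Cl)cc1` is one of two compounds tested so far in a functional assay on SK-MEL-28 cells (Homo sapiens) for cytotoxicity, read by MTT assay (a lower number here means a stronger inhibitor, a higher number a weaker inhibitor), and in this assay compound 2 gives 8450 nM. That is the lower of the two numbers, though only by a hair: its closest neighbour, compound 1 `O=S(=O)(NCCCNc1nccc(-c2c(-c3cccc(F)c3)nc3sccn23)n1)c1cccc(F)c1`, gives 8550 nM in this assay, and the change a 1.0-fold lower number from compound 1 to compound 2 (0.01 log units; within the scatter) is within the scatter, so the two cannot be told apart.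

Compound 3 `O=C(NCCNc1nccc(-c2c(-c3cccc(F)c3)nc3sccn23)n1)c1ccccc1` is the next compound to be measured in this assay. Compared with compound 2, the change is benzamido in place of (((4-chlorophenyl)sulfonyl)amino)methyl on a saturated chain carbon, two bonds along the chain from a nitrogen on an aromatic ring. This is a larger rearrangement of the chain end than anything measured so far. Going by the values given here, the only measured step, from compound 1 to compound 2, exchanged the aromatic ring on the sulfonyl group and produced no shift beyond the scatter, and it says nothing about replacing the sulfonamide-bearing chain by a shorter amide-bearing one. Among the compounds with values here, with no comparable step available, the expectation for compound 3 in this assay is set near the existing numbers, with a wide range: compound 3 is estimated at 8500 nM, between 3000 nM and 25000 nM. This estimate means a step of a 1.0-fold higher number from compound 2 to compound 3 (0.00 log units; within the scatter), expected to fall within the scatter.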

Compound 3, half-maximal inhibitory concentration: 17000 nM
Beside the measured number, compound 3's estimate is 2.0-fold (0.30 log units) below it, and the stated range covers the measured number.
By their numbers in this assay, from the lowest: compounds 2, 1 and 3 (each within the scatter of the next).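

In this assay, benzamido in place of (((4-chlorophenyl)sulfonyl)amino)methyl gives a 2.0-fold higher number from compound 2 to compound 3 (0.30 log units; within the scatter) and benzamido in place of (((3-fluorophenyl)sulfonyl)amino)methyl gives a 2.0-fold higher number from compound 1 to compound 3 (0.30 log units; within the scatter) and so, at this position on a saturated chain carbon, a change of the whole chain end, and not just of the ring on the sulfonyl group, leaves all three compounds within the scatter of one another. The sulfonamide end is therefore not shown to be required for the cytotoxic effect seen here, since a chain end built on a carbonyl gives a number that cannot be told apart from those of compound 1 and compound 2. This single change also alters the chain and the linking group together, so any contribution from either one alone stays hidden, and nothing available explains these numbers.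

Still open, from the compounds shown here alone, is how benzamido would read on the longer chain carried by compound 1 and compound 2, a comparison that would separate the two parts of this change. Also open, going by these compounds, is whether a chain end of another kind, such as an amine or a carboxylic acid, would move the number beyond the scatter.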